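Aryl exchange on the shared core: compound 3 to compound 4

The source may report more compounds than this note shows. Statements on the series, on what has been measured and on what is new or still open speak of the compounds shown alone.

In a functional assay on MKN-45 cells (Homo sapiens) for inhibition, with a stated time of 72 h (on this read-out lower numbers stand for stronger inhibition and higher numbers for weaker inhibition), compound 3 (`COc1ccc(S(=O)(=O)N2CCc3cccc(-c4ccncc4)c32)cc1`) gives 69.5 nM. Compound 2 (`COc1ccc(S(=O)(=O)N2CCc3cccc(-c4ccc(F)c(F)c4)c32)cc1`) gives 55.5 nM, and the comparison shows a 1.3-fold higher number from compound 2 to compound 3 (0.10 log units; within the scatter), so these two cannot be ranked. Compound 1 (`COc1ccc(S(=O)(=O)N2CCc3cccc(-c4ccc(F)nc4)c32)cc1`) gives 145 nM, and compound 3 stands apart from it with a 2.1-fold lower number from compound 1 to compound 3 (0.32 log units; beyond the scatter).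

Compound 4 (`COc1ccc(S(=O)(=O)N2CCc3cccc(-c4ccc(C#N)cc4)c32)cc1`) differs from compound 3 as follows: 4-cyanophenyl in place of pyridin-4-yl on an aromatic carbon. In words, this is 4-cyanophenyl in place of pyridin-4-yl on an aromatic carbon.

Among the measured compounds shown here, no measured compound carries a nitrile, so the evidence is indirect. The exchanges at this same carbon are small, the largest being a 2.6-fold lower number from compound 1 to compound 2 (0.42 log units; beyond the scatter), which is only modest. For the measured compounds named here, the closest precedent for a ring of carbon only replacing pyridin-4-yl is compound 2, and its gap to compound 3 lies within the scatter. On these data alone, no step beyond the scatter is therefore expected, and the direction remains open. The expected step is a 1.1-fold higher number from compound 3 to compound 4 (0.03 log units; within the scatter). The estimate for compound 4 is 75 nM, with an expected range of 30 nM to 190 nM.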

Compound 4, half-maximal inhibitory concentration: 17.2 nM
For compound 4 the middle estimate is 4.4-fold (0.64 log units) above the measured one; measured number outside the range, below it.
By their numbers in this assay, from the lowest: compound 4; then compounds 2 and 3 (each within the scatter of the next); then compound 1.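

In this assay the 4-cyanophenyl exchange on this aromatic carbon gives steps larger than any seen among the earlier groups, with a 4.0-fold lower number from compound 3 to compound 4 (0.61 log units; beyond the scatter) and a 3.2-fold lower number from compound 2 to compound 4 (0.51 log units; beyond the scatter) and also an 8.4-fold lower number from compound 1 to compound 4 (0.93 log units; beyond the scatter), which places compound 4 as the most potent of the four. Among the compounds shown here, a ring of carbon only does not suffice for this gain, since compound 2, with 3,4-difluorophenyl, stays within the scatter of compound 3, so the position separates these aryl groups more sharply than the earlier compounds suggested. Nothing in the data shown accounts for the gain.

On these data alone, it remains open whether the gain depends on the nitrile itself or would also appear with a carboxylic acid, a primary amide or an aminomethyl group in its place. The compounds shown also leave open how the nitrile compares with a methyl group or a chlorine atom on the same phenyl ring.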